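Removing the Ring Fluorine of Compound 2: Expected Tolerance

The compounds below may be only part of what the source reports. "The series", "measured", "known", "first", "only" and "open" are said of these compounds alone.

Measured compounds:
- Compound 1 `CCOC(=O)c1c(-c2ccc(OC)cc2)oc2ccc(OCCCN3C(=O)C(=O)c4cc(F)ccc43)cc12`: 256000 nM
- Compound 2 `CCOC(=O)c1c(-c2ccc(F)cc2)oc2ccc(OCCCN3C(=O)C(=O)c4cc(F)ccc43)cc12`: 512000 nM
- Compound 3 `CCOC(=O)c1c(-c2ccc(F)cc2)oc2ccc(OCCCCCN3C(=O)C(=O)c4cc(OC)ccc43)cc12`: 128000 nM

Of the compounds shown here, three have been measured in an ADME assay on Vero cells (Chlorocebus sabaeus) for cytotoxicity, read by MTT assay, with a stated time of 72 h; a higher number here means that more compound is tolerated, a lower number that less compound is tolerated. Among them compound 2 gives the highest number; compound 1 lies close to it, with a 2.0-fold higher number from compound 1 to compound 2 (0.30 log units; within the scatter), a step within the scatter, while compound 3 sits lower, beyond the scatter of compound 2.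

Compound 4 `CCOC(=O)c1c(-c2ccc(F)cc2)oc2ccc(OCCCN3C(=O)C(=O)c4ccccc43)cc12` has not yet been measured. It differs from compound 2 in one place: hydrogen in place of fluoro on an aromatic carbon. Among the compounds with values here, no measured step in this assay concerns this position; the single step on record, from compound 1 to compound 2, changes a substituent on a different aromatic ring and was itself within the scatter. Compound 3 differs from compound 2 in more than one place and so gives no clean reading on this change.

Within the data shown here, with no direct precedent, the step from compound 2 to compound 4 is expected to stay within the scatter, a 1.3-fold lower number from compound 2 to compound 4 (0.11 log units; within the scatter). Compound 4 is therefore estimated at 400000 nM, with a likely range from 150000 nM to 900000 nM.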

Compound 4, half-maximal cytotoxic concentration: 256000 nM
Estimate against measurement, compound 4: 1.6-fold (0.19 log units) above; low and high end bracket the measured number.
By their numbers in this assay, from the lowest: compounds 3, 1, 4 and 2 (each within the scatter of the next, the first and the last beyond it).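

In this assay, within the data shown here, hydrogen in place of fluoro on an aromatic carbon of the fused system gives a 2.0-fold lower number from compound 2 to compound 4 (0.30 log units; within the scatter), the first reading at this position. It shows that the fluoro can be absent from this carbon without a difference beyond the scatter, so this one-place change, like a 2.0-fold higher number from compound 1 to compound 2 (0.30 log units; within the scatter) on a different aromatic ring, gives no clear separation between the two compounds it links. No measurement on hand gives a cause for this result.

On these data alone, whether a larger or charged group on this carbon, such as an amine or a carboxylic acid, would also stay within the scatter remains open. Also open, as far as these compounds go, is whether removing the fluoro gives a step of similar size when the shared core carries a different substituent elsewhere.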